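Swapping the Sulfur Substituent in a Cytotoxicity Series

This account rests on a few compounds, and the source may have more. Where it says the series, first, only, none or still open, it means among the compounds named here.

Compound 1 `O=C(CSc1nnnn1-c1ccccc1)N/N=c1/scc(-c2ccc(Br)cc2)n1-c1ccccc1`: 47.9%
Compound 2 `O=C(CSc1nnnn1-c1ccccc1)N/N=c1/scc(-c2ccc(F)cc2)n1-c1ccccc1`: 49.3%
Compound 3 `O=C(CSc1nnnn1-c1ccccc1)N/N=c1/scc(-c2ccc(Cl)cc2)n1-c1ccccc1`: 62.3%

In a functional assay on C6 cells (Rattus norvegicus) for cytotoxicity, read by MTT assay, with a stated time of 24 h, tested at 25 ug/mL (on this read-out lower numbers stand for a stronger effect and higher numbers for a weaker effect at the one concentration tested), compound 1 gives the lowest of the three numbers. Compound 2 lies within the scatter of it (a number 1.4 percentage points higher from compound 1 to compound 2 (within the scatter)), while compound 3 sits beyond it (a number 14.4 percentage points higher from compound 1 to compound 3 (beyond the scatter)), as does the step between the other two (a number 13 percentage points higher from compound 2 to compound 3 (beyond the scatter)). Compound 4 `O=C(CSc1ncccn1)N/N=c1/scc(-c2ccc(Br)cc2)n1-c1ccccc1` has not yet been measured. It differs from compound 1 in one place: pyrimidin-2-yl in place of 1-phenyl-1H-tetrazol-5-yl on a sulfur. For the measured compounds named here, all three measured steps vary the halogen on an aromatic carbon and none touches the group on the sulfur, so no measured step bears on this change. For compound 4 a number close to compound 1 is therefore expected, a step of a number 2.1 percentage points higher from compound 1 to compound 4 (within the scatter), in neither direction beyond the scatter. The estimate for compound 4 is 50%, within 33% to 68%.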

Compound 4, a percentage reported as activity, at one concentration (the size of the read-out at that concentration, not a potency): 72.3%
Compound 4: middle estimate off by 22.3 percentage points, on the low side, and the stated range ends below it.
By their numbers in this assay, from the lowest: compounds 1 and 2 (each within the scatter of the next); then compounds 3 and 4 (each within the scatter of the next).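

The group on the sulfur is not silent in this assay: pyrimidin-2-yl in place of 1-phenyl-1H-tetrazol-5-yl gives a number 24.4 percentage points higher from compound 1 to compound 4 (beyond the scatter), a weaker effect at the one concentration tested. On the bromo compounds, then, this position changes the read-out, and the group with one ring gives the weaker effect of the two. Nothing available accounts for this step. The compounds shown leave open whether the same change would carry over to the fluoro and chloro compounds. They also leave open how a simple alkyl chain, an amine or a carboxylic acid on the sulfur would read.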